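A few compounds are considered here, and "the series" means these few. Any claim that something is new, unique, unknown or untested is made for them only; others in the source may bear on it.

Compounds measured so far:
compound 1, `COc1ccc2[nH]c3c(c2c1)CCNC31CCN(Cc2cc(F)cc(Cl)c2)CC1`, 2500 nM in an assay on FRT cells for positive allosteric modulation of Cystic fibrosis transmembrane conductance regulator variant N1303K (Homo sapiens), in the presence of a further agent that is not named here; a lower number here means that less compound is needed, a higher number that more compound is needed for the effect;
compound 2, `COc1ccc2[nH]c3c(c2c1)CCNC31CCN(Cc2ccc(F)c(F)c2)CC1`, 11000 nM in this assay.

Compound 2 gives the higher of the two numbers: its nearest neighbour, compound 1, differs only in the substitution of the phenyl ring, and the change a 4.4-fold higher number from compound 1 to compound 2 (0.64 log units; beyond the scatter) lies beyond the scatter. For the measured compounds named here, compound 3, `COc1ccc2[nH]c3c(c2c1)CCNC31CCN(Cc2cccc(F)c2F)CC1`, keeps the shared core and changes only this ring again: 2,3-difluorophenyl in place of 3,4-difluorophenyl on a saturated chain carbon bound to an amine nitrogen in a ring. Going by the values given here, the one step that bears on it is that from compound 1 to compound 2, which shows that rearranging halogens on this ring can shift this assay by a modest amount; its direction for the present rearrangement cannot be read from a single pair. Compound 3 is therefore expected to land near compound 2, with a 1.2-fold lower number from compound 2 to compound 3 (0.09 log units; within the scatter) as the central guess. The estimate for compound 3 is 9000 nM, with a range from 3000 nM to 30000 nM.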

Compound 3, half-maximal effective concentration: 13600 nM
For compound 3 the middle estimate is 1.5-fold (0.18 log units) below the measured one; low and high end bracket the measured number.
By their numbers in this assay, from the lowest: compound 1; then compounds 2 and 3 (each within the scatter of the next).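

Moving the two fluorines, with 2,3-difluorophenyl entering for 3,4-difluorophenyl on a saturated chain carbon bound to an amine nitrogen in a ring, gives a 1.2-fold higher number from compound 2 to compound 3 (0.09 log units; within the scatter) in this assay, so these two arrangements cannot be told apart here. The comparison with the 3-chloro-5-fluorophenyl group gives a 5.4-fold higher number from compound 1 to compound 3 (0.74 log units; beyond the scatter), which means that both difluorophenyl compounds now stand apart from compound 1, where earlier a single pair showed this. Nothing available on these compounds accounts for that gap.

Compound 1 differs from compound 2 and compound 3 both in carrying chlorine and in where its halogens sit, and the compounds shown do not separate these two differences. Nor do they show how a ring bearing two chlorines, a methoxy group or a trifluoromethyl group would read in this assay.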